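This account rests on a few compounds, and the source may have more. Where it says the series, first, only, none or still open, it means among the compounds named here.

Compound 1 (`COc1cccc(C[C@H]2COC(=O)[C@@H]2Cc2ccc(Cl)c(Cl)c2)c1`) and compound 2 (`COc1ccc(C[C@H]2COC(=O)[C@@H]2Cc2ccc(Cl)c(Cl)c2)cc1O`) share most of their structure and differ in the groups on one aromatic ring. In a functional assay on HL-60 cells (Homo sapiens) for cytotoxicity, read by WST assay, with a stated time of 48 h (on this read-out higher numbers stand for an effect only at larger amounts of compound and lower numbers for an effect already at smaller amounts), compound 1 gives 34000 nM and compound 2 gives 32000 nM. Among the compounds with values here, these two numbers lie within the usual scatter of each other, so compound 2 stands level with the only other measured compound, and neither can be ranked ahead. Within the data shown here, no measured pair differs in a single place, so the data offer no direct precedent for any one change.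

Compound 3 (`COc1ccc(C[C@H]2COC(=O)[C@@H]2Cc2ccc(Cl)c(Cl)c2)cc1OC`) has not yet been measured. It differs from compound 2 in one place: methyl in place of hydrogen on an oxygen on an aromatic ring, which is methyl in place of hydrogen on an oxygen on an aromatic ring, or hydroxy to methoxy. Among the measured compounds shown here, the only guide is that the two measured compounds, despite their different substitution, do not separate in this assay.

No step beyond the scatter is therefore expected in this assay, in either direction, and the estimated change is small: a 1.1-fold lower number from compound 2 to compound 3 (0.03 log units; within the scatter). For compound 3 the estimated value is 30000 nM, with an expected range from 13000 nM to 70000 nM.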

Compound 3, half-maximal effective concentration: 24000 nM
Compound 3: the middle estimate sits 1.3-fold (0.10 log units) above what was measured, and the stated range covers the measured number.
By their numbers in this assay, from the lowest: compounds 3, 2 and 1 (each within the scatter of the next).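

In this assay, putting a methyl in place of the hydrogen on an oxygen on an aromatic ring gives a 1.3-fold lower number from compound 2 to compound 3 (0.12 log units; within the scatter), so at this place, hydroxy and methoxy do not separate, and the free hydrogen on that oxygen is not needed for the cytotoxicity seen here. The second single-place comparison, methoxy in place of hydrogen on an aromatic carbon, gives a 1.4-fold lower number from compound 1 to compound 3 (0.15 log units; within the scatter), so this change also leaves the compounds level, and both ways of arriving at compound 3 point to the same flat picture for these substituents. Nothing measured alongside these numbers speaks to why the two changes leave the read-out where it is.

Going by these compounds, all three compounds carry only hydroxy or methoxy groups on this aromatic ring, and they remain within the scatter of one another, so it stays open whether any change on this ring can move the number at all. An amine, a carboxylic acid or a longer chain such as ethoxy at the same oxygen might behave differently, and the compounds shown give no guide to whether any of them would stand apart from compound 3.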